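The source may hold more compounds than are shown below. What is called first, only, known or untested is meant among the compounds shown, and "the series" means these compounds.

Of the compounds shown here, three sharing one core have been measured in a functional assay on RS4-11 cells (Homo sapiens) for inhibition, read by CCK-8 assay, with a stated time of 48 h, tested at 20 uM; a lower number here means less inhibition of growth, a higher number more inhibition of growth at the concentration tested. Compound 1 `N#C/C(=C\c1ccccc1OS(=O)(=O)c1ccccc1[N+](=O)[O-])C(=O)Nc1nnc(Cc2cccc3ccccc23)s1` gives 66% in this assay. Compound 2 `N#C/C(=C\c1ccccc1OS(=O)(=O)c1ccc(F)cc1)C(=O)Nc1nnc(Cc2cccc3ccccc23)s1` gives 68% in this assay. Compound 3 `N#C/C(=C\c1ccccc1OS(=O)(=O)c1ccccc1[N+](=O)[O-])C(=O)Nc1nnc(Cc2cccc(F)c2)s1` gives 68% in this assay. Compound 2 and compound 3 are level at the digits read, and both sit within the scatter of compound 1.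

The change from compound 1 to compound 2 is 4-fluorophenyl in place of 2-nitrophenyl on a sulfonyl sulfur; it made a step of a number 2 percentage points higher from compound 1 to compound 2 (within the scatter). The step from compound 1 to compound 3 is a number 2 percentage points higher from compound 1 to compound 3 (within the scatter). Neither step leaves the scatter, so no ranking among the three is supported.

Compound 4 `N#C/C(=C\c1ccccc1OS(=O)(=O)c1ccc(F)cc1)C(=O)Nc1nnc(Cc2cccc(F)c2)s1` awaits measurement in this assay. It differs from compound 3 by 4-fluorophenyl in place of 2-nitrophenyl on a sulfonyl sulfur, which is the same change as that from compound 1 to compound 2; the place lines match word for word, and the change occurs twice among the compounds shown. The two cores on which it is made differ by 3-fluorophenyl in place of naphthalen-1-yl on a saturated chain carbon bound to an aromatic carbon.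

The expectation for compound 4 rests on a single earlier occurrence: on the core of compound 1 the change produced a number 2 percentage points higher from compound 1 to compound 2 (within the scatter), and the step from compound 3 to compound 4 is expected to be a number 2 percentage points higher from compound 3 to compound 4 (within the scatter). Because compound 3 gives 68%, compound 4 is estimated at 70% in this assay. The expected range for compound 4 runs from 58% to 82%.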

Compound 4, percent growth inhibition at one concentration: 72%
Compound 4: middle estimate off by 2 percentage points, on the low side; low and high end bracket the measured number.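

In this assay, 4-fluorophenyl in place of 2-nitrophenyl on a sulfonyl sulfur gives a number 4 percentage points higher from compound 3 to compound 4 (within the scatter), and on the two cores this change reads alike: the same change on two cores in this assay, a number 2 percentage points higher (within the scatter) from compound 1 to compound 2 and a number 4 percentage points higher (within the scatter) from compound 3 to compound 4, 2 percentage points apart, within the scatter of two such steps

The second change, 3-fluorophenyl in place of naphthalen-1-yl on a saturated chain carbon bound to an aromatic carbon, gives a number 4 percentage points higher from compound 2 to compound 4 (within the scatter), and it also reads alike on its two cores: the same change on two cores in this assay, a number 2 percentage points higher (within the scatter) from compound 1 to compound 3 and a number 4 percentage points higher (within the scatter) from compound 2 to compound 4, 2 percentage points apart, within the scatter of two such steps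

So neither change shows a detectable dependence on the core it is made on, but this is weak support for transfer: every step lies within the scatter, which means these compounds show neither change to have any effect of its own and cannot show that a real effect would carry from one core to another.

Still open, going by these compounds, is whether any group at either place gives a step beyond the scatter, for instance an amine in place of the aromatic group on the sulfonyl sulfur, or a carboxylic acid or a longer chain in place of the aromatic group on the saturated chain carbon. Also open, on these data alone, is whether these compounds would separate at other concentrations, since a reading at one concentration gives no ranking among them.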